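The source may hold more compounds than are shown below. What is called first, only, known or untested is meant among the compounds shown, and "the series" means these compounds.

Two members of the shared core have been measured in a functional assay on A549 cells (Homo sapiens) for cytotoxicity, read by sulforhodamine B assay, with a stated time of 48 h; on this read-out lower numbers stand for higher toxicity in this test and higher numbers for lower toxicity in this test. Compound 2 `COC(=O)[C@@H]1C[C@@]2(CC=C(C)C)c3ccccc3N3C(=N)[C@H](Cc4ccccc4)N1[C@H]32` gives 24100 nM; compound 1 `C=CC[C@@]12C[C@@H](C(=O)OC)N3[C@@H]1N(C(=N)C31CCCCC1)c1ccccc12` gives 25200 nM. The two values sit within the usual scatter of each other, so no order between them can be read from these numbers.

Compound 3 `COC(=O)[C@@H]1C[C@@]2(CC=C(C)C)c3ccccc3N3C(=N)[C@H](C(C)(C)C)N1[C@H]32` carries the change (tert-butyl in place of benzyl on a saturated ring carbon), tert-butyl in place of benzyl on a saturated ring carbon. Going by the values given here, no measured pair with this change exists, so the size of the step cannot be taken from data. Given that compound 2 sits beside compound 1, which with a different group at the same part of the core gives 25200 nM, compound 3 is expected at 25000 nM, within 10000 nM to 60000 nM, the estimated step of a 1.0-fold higher number from compound 2 to compound 3 (0.02 log units; within the scatter) being none beyond the scatter.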

Compound 3, concentration lethal to 50% of the cells: > 100000 nM
Compound 3 was reported as a limit; the forecaster's own chance of this, stated with the estimate: 10%; at least 4.0-fold (0.60 log units) between middle value and limit.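

Unlike the earlier values, which lay within the scatter of each other, this result shows that the group on this saturated ring carbon can shift the read-out in this assay. Tert-butyl in place of benzyl gives an at least 4.1-fold higher number from compound 2 to compound 3 (0.61 log units; beyond the scatter) and is the only readable step in the series so far. Compound 3 stands as a limit of the assay, not as a number: the limit of > 100000 nM in this assay, at which 1 of the 3 values shown sits.

Going by these compounds, whether a longer chain or an amine on this carbon would read like benzyl or like tert-butyl stays open. On these data alone, the full size of the step also stays open.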